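The source may hold more compounds than are shown below. What is called first, only, known or untested is meant among the compounds shown, and "the series" means these compounds.

Measured compounds in an ADME assay on the whole organism (Mus musculus, strain ICR) for metabolic stability, read by LC-MS, with a stated time of 24 h, at a dose of 10 mg/kg by the oral route; on this read-out lower numbers stand for a shorter-lived compound and higher numbers for a longer-lived compound:
compound 1 `CCN1CCN(c2cc(Nc3cc(C)nn3C(=O)C(C)(C)C)nc(N[C@H]3CCN(C(=O)c4ccc(Cl)cc4F)C3)n2)CC1`, which gives 2.2 h;
compound 2 `CCOC(=O)n1nc(C)cc1Nc1cc(N2CCN(CC)CC2)nc(N[C@H]2CCN(C(=O)c3ccc(Cl)cc3F)C2)n1`, which gives 2.7 h;
compound 3 `CCN1CCN(c2cc(Nc3cc(C)[nH]n3)nc(N[C@H]3CCN(C(=O)c4ccc(Cl)cc4F)C3)n2)CC1`, which gives 1.6 h.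

Compound 3 holds the lowest of the three numbers, yet its distance from the other two is small: a 1.4-fold lower number from compound 1 to compound 3 (0.14 log units; within the scatter) and a 1.7-fold lower number from compound 2 to compound 3 (0.23 log units; within the scatter), so the three compounds cannot be put in any order on this assay.

Compound 4 `CCOC(=O)n1nc(Nc2cc(N3CCN(CC)CC3)nc(N[C@H]3CCN(C(=O)c4ccc(Cl)cc4F)C3)n2)cc1C` has not yet been measured. It differs from compound 3 in one place: ethoxycarbonyl in place of hydrogen on an aromatic nitrogen. For the measured compounds named here, the measured step that bears most closely on this change is the one from compound 2 to compound 3, where the same kind of group, ethoxycarbonyl, was removed from an aromatic nitrogen of the same pyrazole, although the products are not identical; that step read a 1.7-fold lower number from compound 2 to compound 3 (0.23 log units; within the scatter), within the scatter. The step of a 1.2-fold higher number from compound 1 to compound 2 (0.09 log units; within the scatter) adds nothing beyond the scatter either. On this basis only a small step, if any, is expected, and in this assay compound 4 is estimated at 2.3 h, within a range of 1.3 h to 4 h. The expected step of a 1.4-fold higher number from compound 3 to compound 4 (0.16 log units; within the scatter) would, in this estimate, stay within the scatter.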

Compound 4, half-life: 2.3 h
Estimate against measurement, compound 4: no gap at the digits printed, within the range that was stated.
By their numbers in this assay, from the lowest: compounds 3, 1, 4 and 2 (each within the scatter of the next).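

In this assay, placing ethoxycarbonyl in place of hydrogen on the aromatic nitrogen gives a 1.4-fold higher number from compound 3 to compound 4 (0.16 log units; within the scatter), so this exact change, which earlier could be judged only through a related pair of compounds, now has a direct reading and does not separate the two compounds. The two ring arrangements, 1-(ethoxycarbonyl)-5-methyl-1H-pyrazol-3-yl and 1-(ethoxycarbonyl)-3-methyl-1H-pyrazol-5-yl, also cannot be told apart, with a 1.2-fold lower number from compound 2 to compound 4 (0.07 log units; within the scatter). Comparing 1-(ethoxycarbonyl)-5-methyl-1H-pyrazol-3-yl with 3-methyl-1-((tert-butyl)carbonyl)-1H-pyrazol-5-yl gives a 1.0-fold higher number from compound 1 to compound 4 (0.02 log units; within the scatter), so all of the changes at this part of the molecule remain too small to rank the compounds.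

The data shown offer no measured explanation for where any of these numbers fall. As far as these compounds go, it remains open whether a different group on this aromatic nitrogen, such as a plain methyl or a longer chain ending in an amine, would produce a step beyond the scatter in this assay.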